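A Methyl-to-Hydrogen Step Carried Onto a Second Core

The source may hold more compounds than are shown below. What is called first, only, known or untested is meant among the compounds shown, and "the series" means these compounds.

Measured compounds:
Compound 1 `COc1ccc(/C=C2\COc3ccccc3C2=O)cc1O`: 479000 nM
Compound 2 `O=C1/C(=C/c2ccc(O)c(O)c2)COc2ccccc21`: 141000 nM
Compound 3 `COc1ccc(C(=O)/C=C/c2ccc(Cl)cc2)cc1`: 53700 nM

All three were tested in an assay on isolated protein for inhibition of Amine oxidase [flavin-containing] B (Homo sapiens) (a lower number here means a stronger inhibitor, a higher number a weaker inhibitor), and all of them are weak. Compound 1 and compound 2 share a core and differ by one change, (hydrogen in place of methyl on an oxygen on an aromatic ring), which gave a 3.4-fold lower number from compound 1 to compound 2 (0.53 log units; beyond the scatter). Compound 3 is built on another core; the difference between the two cores is not broken down here. Among the three, compound 3 has the lowest number, and compound 2 comes nearest to it.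

Compound 4 `O=C(/C=C/c1ccc(Cl)cc1)c1ccc(O)cc1` is compound 3 after the change (hydrogen in place of methyl on an oxygen on an aromatic ring). Among the measured compounds shown here, this is the same change as the one from compound 1 to compound 2, made at the same kind of place on an oxygen on an aromatic ring, but here on a different core. For the measured compounds named here, the only guide is the one earlier step, which rests on the step of a 3.4-fold lower number from compound 1 to compound 2 (0.53 log units; beyond the scatter), and the change on compound 3 is expected to move the number in the same direction by a 3.0-fold lower number from compound 3 to compound 4 (0.47 log units; beyond the scatter). Going by the values given here, compound 4 is therefore estimated at 18000 nM in this assay, with a plausible range from 6000 nM to 50000 nM, wide because the one prior example a 3.4-fold lower number from compound 1 to compound 2 (0.53 log units; beyond the scatter) lies on another core and is thin evidence.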

Compound 4, half-maximal inhibitory concentration: 30900 nM
Beside the measured number, compound 4's estimate is 1.7-fold (0.23 log units) below it; the range from low to high includes it.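

In this assay, going from methoxy to hydroxy on the second core gives a 1.7-fold lower number from compound 3 to compound 4 (0.24 log units; within the scatter), so on this core alone the step cannot be told apart from the ordinary spread of repeated measurements. Set beside the earlier step, the result does not show that the change behaves differently on the two cores: the same change on two cores in this assay, a 3.4-fold lower number (0.53 log units; beyond the scatter) from compound 1 to compound 2 and a 1.7-fold lower number (0.24 log units; within the scatter) from compound 3 to compound 4, 2.0-fold (0.29 log units) apart, within the scatter of two such steps. The two steps are therefore compatible with a change that carries over from one core to the other, but two pairs, one of them inside the scatter, do not prove that it does, or that its size is the same on both cores.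

The compounds shown carry only methoxy or hydroxy on this oxygen, so it remains open how a longer chain such as ethoxy, or an amine in that place, would read on either core. Going by these compounds, whether any other change on these cores could reach a much lower number also remains open.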